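Aminoquinoline ethers: acyclic ether in place of cyclopentylmethyl

The compounds below may be only part of what the source reports. "The series", "measured", "known", "first", "only" and "open" are said of these compounds alone.

For the measured compounds named here, compound 1 `Nc1ccc2cccc(OCC3CCCC3)c2n1` stands lowest of the two numbers measured so far: in an assay on cells with melanin-concentrating hormone receptor 1 (Homo sapiens) as the target, read by radioligand binding (on this read-out higher numbers stand for weaker inhibition and lower numbers for stronger inhibition), compound 1 gives 53 nM. Compound 2 `CCC(CC)C(C)Oc1cccc2ccc(N)nc12` gives 191 nM in this assay, a higher number than compound 1 and beyond the usual scatter. Compound 3 `CCOCC(C)Oc1cccc2ccc(N)nc12` has not yet been measured; it differs from compound 1 by a group of 6 heavy atoms (5 carbon, 1 oxygen; no ring) in place of a group of 6 heavy atoms (6 carbon; one five-membered non-aromatic ring of carbon only), on an oxygen on an aromatic ring. Going by the values given here, no step between measured compounds carries this change, so the expected step from compound 1 to compound 3 is a 2.1-fold higher number from compound 1 to compound 3 (0.32 log units; beyond the scatter), a small loss at most, possibly within the scatter. Compound 3 is estimated at 110 nM, within 40 nM to 350 nM.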

Compound 3, half-maximal inhibitory concentration: 1070 nM
Compound 3: the middle estimate sits 9.7-fold (0.99 log units) below what was measured; the whole stated range lies below it.
By their numbers in this assay, from the lowest: compound 1; then compound 2; then compound 3.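

Cyclopentylmethyl on the oxygen on an aromatic ring gives way poorly to the acyclic group carrying a hydrogen-bond acceptor: in this assay the change is a 20-fold higher number from compound 1 to compound 3 (1.31 log units; beyond the scatter). Among the acyclic ethers, ethoxymethyl in place of pentan-3-yl still gives a 5.6-fold higher number from compound 2 to compound 3 (0.75 log units; beyond the scatter), so the open chains do not all sit at one level. Nothing available explains either loss.

On these data alone, whether the chain oxygen itself tracks with the loss stays open: a propyl chain in place of ethoxymethyl would test that. As far as these compounds go, how an amine or a hydroxyl on this chain would read is equally open.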